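Chain extension on the ketone of compound 3

The compounds below may be only part of what the source reports. "The series", "measured", "known", "first", "only" and "open" are said of these compounds alone.

Measured so far:
compound 1 `COC(=O)C1=CCCCC1S(=O)(=O)Cc1ccc(F)cc1Cl` — 99 nM
compound 2 `CCCOC(=O)C1=CCCCC1S(=O)(=O)Cc1ccc(F)cc1Cl` — 14 nM
compound 3 `CCC(=O)C1=CCCCC1S(=O)(=O)Cc1ccc(F)cc1Cl` — 64 nM

In a functional assay on RAW264.7 cells (Mus musculus), read by fluorescence (on this read-out higher numbers stand for weaker inhibition and lower numbers for stronger inhibition), compound 3 stands second highest of the three; the gap to compound 1 is within the scatter, while a 4.6-fold higher number from compound 2 to compound 3 (0.66 log units; beyond the scatter) is beyond it. Compound 4 `CCCC(=O)C1=CCCCC1S(=O)(=O)Cc1ccc(F)cc1Cl` differs from compound 3 by methyl in place of hydrogen on a saturated chain carbon, two bonds along the chain from a carbonyl carbon. Going by the values given here, the only step that lengthens a chain here is a 7.1-fold lower number from compound 1 to compound 2 (0.85 log units; beyond the scatter), a chain extension that lowered the number; a 1.5-fold lower number from compound 1 to compound 3 (0.19 log units; within the scatter) adds little. On that basis a modest lowering is expected for compound 4, a 2.0-fold lower number from compound 3 to compound 4 (0.30 log units; within the scatter), though the bearing of an ester-side extension on a ketone chain is uncertain. Compound 4 is therefore estimated at 32 nM in this assay, with a range from 12 nM to 85 nM.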

Compound 4, half-maximal inhibitory concentration: 11 nM
Beside the measured number, compound 4's estimate is 2.9-fold (0.46 log units) above it; the whole stated range lies above it.
By their numbers in this assay, from the lowest: compounds 4 and 2 (each within the scatter of the next); then compounds 3 and 1 (each within the scatter of the next).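

In this assay, going by these compounds alone, methyl in place of hydrogen on the saturated chain carbon, two bonds along the chain from the carbonyl carbon, gives a 5.8-fold lower number from compound 3 to compound 4 (0.76 log units; beyond the scatter); the ketone series thus also responds to chain extension, which the earlier compounds showed only on the ester side. Propyl in place of propoxy gives a 1.3-fold lower number from compound 2 to compound 4 (0.10 log units; within the scatter), so the propyl ketone and propyl ester stand level, while propyl in place of methoxy gives a 9.0-fold lower number from compound 1 to compound 4 (0.95 log units; beyond the scatter). No available data explain these steps.

From the compounds shown here alone, whether a butyl or longer chain continues this trend remains open, as does the effect of a branched chain or a terminal amine.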